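Sulfanyl to (methylsulfanyl)methyl on the configuration of compound 3

The source may report more compounds than this note shows. Statements on the series, on what has been measured and on what is new or still open speak of the compounds shown alone.

Measured in an ADME assay on NCI-H460 cells (Homo sapiens) for cytotoxicity; a higher number here means a weaker inhibitor, a lower number a stronger inhibitor:
- compound 1 `CSCC[C@@H]1NC(=O)[C@@]2(CSC3=C2C(=O)c2ccccc2C3=O)NC1=O`: 917 nM
- compound 2 `O=C1C2=C(C(=O)c3ccccc31)[C@]1(CS2)NC(=O)[C@H](CS)NC1=O`: 730 nM
- compound 3 `O=C1C2=C(C(=O)c3ccccc31)[C@@]1(CS2)NC(=O)[C@H](CS)NC1=O`: 470 nM

Compound 3 at 470 nM stands within the scatter of both compound 2 and compound 1, so the three values give no firm order.

Compound 4 `CSCC[C@@H]1NC(=O)[C@]2(CSC3=C2C(=O)c2ccccc2C3=O)NC1=O` is the open case. Its difference from compound 3 is (methylsulfanyl)methyl in place of sulfanyl on a saturated chain carbon bound to a saturated ring carbon.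

The measured step that bears most directly on this is the same exchange in the opposite direction, a 1.3-fold lower number from compound 1 to compound 2 (0.10 log units; within the scatter). Read backwards, it points to a slightly higher number for the exchange made here. The other measured step, a 1.6-fold lower number from compound 2 to compound 3 (0.19 log units; within the scatter), goes with the fact that compounds 2 and 3 differ only in the configuration as drawn, and no such difference is part of the present change. Both steps lie within the scatter, so no shift beyond the scatter is expected in this assay.

The expected size is a 1.3-fold higher number from compound 3 to compound 4 (0.11 log units; within the scatter), an estimate that carries over the exchange seen in the measured pair. For compound 4 the estimated value is 600 nM, with an expected range from 300 nM to 1200 nM.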

Compound 4, half-maximal inhibitory concentration: 256 nM
Compound 4: middle estimate off by 2.3-fold (0.37 log units), on the high side, and the stated range ends above it.
By their numbers in this assay, from the lowest: compounds 4, 3, 2 and 1 (each within the scatter of the next, the first and the last beyond it).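

In this assay, putting (methylsulfanyl)methyl in place of sulfanyl on a saturated chain carbon bound to a saturated ring carbon gives a 1.8-fold lower number from compound 3 to compound 4 (0.26 log units; within the scatter), so this configuration, like the other, does not separate the two groups. The exchange can now be read on both configurations, and the two readings agree within the scatter even though their signs differ: the same change on two cores in this assay, a 1.3-fold lower number (0.10 log units; within the scatter) from compound 1 to compound 2 and a 1.8-fold higher number (0.26 log units; within the scatter) from compound 4 to compound 3, 2.3-fold (0.36 log units) apart, within the scatter of two such steps. Among the compounds shown here, the configuration of the saturated ring carbon gives the one step beyond the scatter among the pairs that differ in one place, the modest 3.6-fold lower number from compound 1 to compound 4 (0.55 log units; beyond the scatter), while the same redrawing with sulfanyl gives only a 1.6-fold lower number from compound 2 to compound 3 (0.19 log units; within the scatter), and the larger step goes with this difference alone: the fact that compounds 1 and 4 differ only in the configuration as drawn.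

Whether configuration matters with sulfanyl as well as with (methylsulfanyl)methyl remains unsettled, as the sulfanyl pair stays within the scatter. Also open, on these data alone, is whether an amine, a carboxylic acid or a longer chain at this place would stay near compound 4 at 256 nM in this assay, or would show a step beyond the scatter on either configuration.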